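Chloropyrimidine anilines: replacing the ring chlorine with a selenocyanato chain

This account rests on a few compounds, and the source may have more. Where it says the series, first, only, none or still open, it means among the compounds named here.

Measured so far in a functional assay on HCT-116 cells (Homo sapiens) for antiproliferative activity, read by MTT assay, with a stated time of 48 h; a higher number here means a weaker inhibitor, a lower number a stronger inhibitor:
compound 1 `COc1ccc(N(C)c2ccnc(Cl)n2)cc1Cl`: 1170 nM
compound 2 `COc1ccc(N(C)c2ccnc(Cl)n2)cc1[N+](=O)[O-]`: 4700 nM
compound 3 `COc1ccc(N(C)c2ccnc(Cl)n2)cc1OCCCBr`: 1970 nM

Compound 1 carries the lowest number of the three. Its nearest neighbour is compound 3, a 1.7-fold higher number from compound 1 to compound 3 (0.23 log units; within the scatter), so the two cannot be ordered. Compound 2 stands furthest off, a 4.0-fold higher number from compound 1 to compound 2 (0.60 log units; beyond the scatter). Between compound 2 and compound 3 the step is a 2.4-fold lower number from compound 2 to compound 3 (0.38 log units; beyond the scatter).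

Compound 4 `COc1ccc(N(C)c2ccnc(Cl)n2)cc1OCCC[Se]C#N` is the next member. It differs from compound 1 in one place: a group of 7 heavy atoms (4 carbon, 1 nitrogen, 1 oxygen, 1 selenium; no ring) in place of one chlorine atom, on an aromatic carbon

Among the compounds with values here, the one measured step that bears on this change is the one from compound 1 to compound 3, where the chlorine was also exchanged for a three-carbon propoxy chain ending in a bromine rather than a selenocyanate; that step stayed within the scatter. The step from compound 1 to compound 2, a nitro for the chlorine, is of a different kind and weighs less here. The terminus of the chain is new to the series, so the expectation rests on one step. For compound 4 the number in this assay is expected to stay close to that of compound 1, with no step beyond the scatter, and the expected step is a 1.3-fold higher number from compound 1 to compound 4 (0.11 log units; within the scatter). The estimate for compound 4 is 1500 nM, in the range 500 nM to 4500 nM.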

Compound 4, half-maximal inhibitory concentration: 3920 nM
The estimate for compound 4 lay 2.6-fold (0.42 log units) below the measured number, within the range that was stated.
By their numbers in this assay, from the lowest: compounds 1, 3, 4 and 2 (each within the scatter of the next, the first and the last beyond it).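

In this assay, on the aromatic carbon ortho to a methoxy group, a propoxy chain ending in a selenocyanate in place of chloro gives a 3.4-fold higher number from compound 1 to compound 4 (0.53 log units; beyond the scatter) as a step beyond the scatter, which the bromine-ended chain at the same place did not give. The chain terminus alone does not separate the two chain compounds, since a 2.0-fold higher number from compound 3 to compound 4 (0.30 log units; within the scatter) stays within the scatter, so selenocyanate and bromine at the chain end cannot be ordered, even though only compound 4 of the two lies beyond the scatter from compound 1. The chain with the selenocyanate also cannot be told apart from the nitro group, as a 1.2-fold lower number from compound 2 to compound 4 (0.08 log units; within the scatter) stays within the scatter, and compounds 2 and 4 therefore both sit beyond the scatter from compound 1 at this position.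

Open, from the compounds shown here alone, is whether a shorter or longer chain, or an amine or a thiocyanate at the chain end, would stay with compound 1 or with compounds 2 and 4. Nothing available on these compounds accounts for the step away from chloro.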